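Dropping the carbonyl before the ethylpiperazine ring

The source may report more compounds than this note shows. Statements on the series, on what has been measured and on what is new or still open speak of the compounds shown alone.

Going by the values given here, in an ADME assay on microsomes from liver (Homo sapiens) for metabolic stability, with a stated time of 30 min, tested at 1 uM (a higher number here means that more of the compound is left, a lower number that less of the compound is left), compound 1 `CCN1CCN(C(=O)c2ccc(Nc3ncc4c(n3)N(C)C(=O)N(c3cc(NC(=O)c5cccc(C(F)(F)F)c5)ccc3C)C4)cn2)CC1` gives 24.6%, the lower of the two numbers so far. Compound 2 `Cc1ccc(Nc2ncc3c(n2)N(C)C(=O)N(c2cc(NC(=O)c4ccc(CN5CCC(N(C)C)C5)c(C(F)(F)F)c4)ccc2C)C3)cn1` gives 57.5%, a gap beyond the scatter, but compound 2 differs from compound 1 in more than one place. Compound 3 `CCN1CCN(c2ccc(Nc3ncc4c(n3)N(C)C(=O)N(c3cc(NC(=O)c5cccc(C(F)(F)F)c5)ccc3C)C4)cn2)CC1` has 4-ethylpiperazin-1-yl in place of (4-ethylpiperazin-1-yl)carbonyl on an aromatic carbon, with the rest of compound 1 unchanged: 4-ethylpiperazin-1-yl in place of (4-ethylpiperazin-1-yl)carbonyl on an aromatic carbon. Among the compounds with values here, no measured pair isolates this change, so the data offer no direct guide to its size. The best anchor is compound 1 at 24.6%, and no shift beyond the scatter is expected. The expected change is a slight rise, estimated as a number 5.4 percentage points higher from compound 1 to compound 3 (within the scatter). For compound 3 the expected value is 30%, with an estimated range of 12% to 50%.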

Compound 3, percent of the compound remaining: 29.8%
Compound 3: middle estimate off by 0.2 percentage points, on the high side, within the range that was stated.
By their numbers in this assay, from the lowest: compounds 1 and 3 (each within the scatter of the next); then compound 2.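

In this assay the first pair differing in one place, on an aromatic carbon next to the ring nitrogen, gives a number 5.2 percentage points higher from compound 1 to compound 3 (within the scatter) and so isolates the carbonyl before the ethylpiperazine ring. On the core of compound 1, 4-ethylpiperazin-1-yl and (4-ethylpiperazin-1-yl)carbonyl therefore cannot be told apart by this read-out, and this single pair gives no sign that the carbonyl matters here. Nothing available explains the size of this step.

Open, from the compounds shown here alone, is whether a methylene link in place of the carbonyl, or a morpholin-4-yl ring in place of the ethylpiperazine, would give a step beyond the scatter at this aromatic carbon. Also open, going by these compounds, is whether a longer chain than ethyl on the piperazine nitrogen would move the number on this core.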